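The source may hold more compounds than are shown below. What is called first, only, known or untested is meant among the compounds shown, and "the series" means these compounds.

In a functional assay on HT-29 cells (Homo sapiens) for inhibition, in the presence of a further agent that is not named here (a higher number here means a weaker inhibitor of growth, a lower number a stronger inhibitor of growth), compound 1 (`CCc1nc(N)nc(N)c1-c1ccc(NCc2ccccc2OC)c([N+](=O)[O-])c1`) gives 11600 nM. Compound 2 (`CCc1nc(N)nc(N)c1-c1ccc2[nH]c(-c3ccc(Cl)cc3)[n+]([O-])c2c1`) stands at > 50000 nM, which is a limit of the assay and not a number. Compound 3 (`CCc1nc(N)nc(N)c1-c1ccc2[nH]c(-c3ccc(F)cc3)[n+]([O-])c2c1`) differs from compound 2 in one place, with fluoro in place of chloro on an aromatic carbon. For the measured compounds named here, no measured step bears on this change, and no step beyond the scatter is expected in this assay, in either direction. The estimated step is a number no higher from compound 2 to compound 3 (the limit leaves the size open). The estimate for compound 3 is 50000 nM, expected to lie between 20000 nM and 100000 nM.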

Compound 3, concentration for 50% growth inhibition: 39000 nM
The estimate for compound 3 lay 1.3-fold (0.11 log units) above the measured number, within the range that was stated.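

Fluoro at this position yields a readable number: in this assay compound 3 gives 39000 nM. The change amounts to an at least 1.2-fold lower number from compound 2 to compound 3 (0.10 log units; that floor lies within the scatter), so only a floor on its size is known, and it does not show that fluoro and chloro differ here. The true size stays open because compound 2 rests on a limit of the assay and not on a number: the limit of > 50000 nM in this assay, at which 1 of the 3 values shown sits.

On these data alone, whether an amine, a methoxy group or a plain hydrogen in this place would shift the number beyond the scatter remains open.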